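The compounds below may be only part of what the source reports. "The series", "measured", "known", "first", "only" and "open" are said of these compounds alone.

Measured compounds in a functional assay on NCI-H522 cells (Homo sapiens) for inhibition, read by sulforhodamine B assay, with a stated time of 48 h; on this read-out higher numbers stand for weaker inhibition of growth and lower numbers for stronger inhibition of growth:
compound 1 `Nc1cc(N)c2nc(-c3ccccc3)c(Oc3ccc(Cl)c(Cl)c3)nc2c1`: 8320 nM
compound 2 `COc1cc(CNc2nc3cc(N)cc(N)c3nc2-c2ccccc2)cc(OC)c1OC`: < 50200 nM, which is a limit of this assay and not a number

Going by the values given here, compound 1 holds the only numerical value in this assay. For compound 2 the result is a limit only, and it sits at the limit of < 50200 nM in this assay, at which 1 of the 2 values shown sits. Among the compounds with values here, no pair of measured compounds differs in a single place, so no measured step is available to calibrate the change that follows.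

Compound 3 `COc1ccc(Sc2nc3cc(N)cc(N)c3nc2-c2ccccc2)cc1` differs from compound 1 by (4-methoxyphenyl)sulfanyl in place of 3,4-dichlorophenoxy on an aromatic carbon. Without a measured step of this kind, the expected step from compound 1 to compound 3 is small, a 1.1-fold higher number from compound 1 to compound 3 (0.03 log units; within the scatter), not clearly beyond the scatter in either direction. Compound 3 is therefore expected to give about 9000 nM in this assay, with a range from 2500 nM to 32000 nM.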

Compound 3, concentration for 50% growth inhibition: 3240 nM
Compound 3: the middle estimate sits 2.8-fold (0.44 log units) above what was measured, within the range that was stated.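

In this assay, going by these compounds alone, the aromatic carbon next to the ring nitrogen and ortho to a phenyl group proves open to change: (4-methoxyphenyl)sulfanyl in place of 3,4-dichlorophenoxy gives a 2.6-fold lower number from compound 1 to compound 3 (0.41 log units; beyond the scatter) in the first single-place comparison of the series. Growth inhibition is therefore kept at this position, and modestly strengthened, with the aryl ring attached through sulfur rather than oxygen and carrying methoxy rather than chlorine. No measurement shown accounts for this step.

The linking atom and the ring substituents change together here, and the compounds shown do not separate their contributions. Also open, on these data alone, is how this position responds to an amine or a carboxylic acid on the aryl ring, or to a longer chain in place of the aryl group.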